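Ether replacements for the hydroxypropanoate on the side chain

This account rests on a few compounds, and the source may have more. Where it says the series, first, only, none or still open, it means among the compounds named here.

Going by the values given here, compound 1 `CC(C)=CC[C@@H](OC(=O)CCO)C1=CC(=O)c2c(O)ccc(O)c2C1=O` gives 55300 nM in a functional assay on DU-145 cells (Homo sapiens) for cytotoxicity, read by MTT assay (a lower number here means a stronger inhibitor, a higher number a weaker inhibitor), the highest of the two numbers measured so far. Among the compounds with values here, compound 2 `COC(C)CO[C@H](CC=C(C)C)C1=CC(=O)c2c(O)ccc(O)c2C1=O` gives 16600 nM in this assay; the only measured step is a 3.3-fold lower number from compound 1 to compound 2 (0.52 log units; beyond the scatter). Compound 3 `CC(C)=CC[C@@H](OC[C@@H](C)O)C1=CC(=O)c2c(O)ccc(O)c2C1=O` differs from compound 1 by 2-hydroxypropyl in place of (2-hydroxyethyl)carbonyl on an oxygen on a saturated carbon. Both changes remove the (2-hydroxyethyl)carbonyl at the same oxygen on a saturated carbon, and the entering 2-hydroxypropyl resembles the 2-methoxypropyl of compound 2, so a modest lowering is expected. The expected step is a 2.5-fold lower number from compound 1 to compound 3 (0.40 log units; beyond the scatter). Compound 3 is thus estimated at 22000 nM in this assay, with a range of 8000 nM to 60000 nM.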

Compound 3, half-maximal inhibitory concentration: 14300 nM
Compound 3: the middle estimate sits 1.5-fold (0.19 log units) above what was measured, within the range that was stated.
By their numbers in this assay, from the lowest: compounds 3 and 2 (each within the scatter of the next); then compound 1.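

With 2-hydroxypropyl on the oxygen on a saturated carbon, a 3.9-fold lower number from compound 1 to compound 3 (0.59 log units; beyond the scatter) in this assay, so a second replacement for (2-hydroxyethyl)carbonyl moves the same way as the 2-methoxypropyl of compound 2. Exchanging 1-methoxyethyl for 1-hydroxyethyl gives a 1.2-fold lower number from compound 2 to compound 3 (0.06 log units; within the scatter), so these two groups are not told apart here. No available evidence gives a reason for either step.

From the compounds shown here alone, whether an amine, a carboxylic acid or a longer chain at this oxygen would follow these two ethers remains open. So does the role of the defined stereocentre in 2-hydroxypropyl.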